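A few compounds are considered here, and "the series" means these few. Any claim that something is new, unique, unknown or untested is made for them only; others in the source may bear on it.

Measured in a functional assay on MCF7 cells (Homo sapiens) for antiproliferative activity, read by MTT assay, with a stated time of 72 h; a higher number here means a weaker inhibitor, a lower number a stronger inhibitor:
- compound 1 `COc1cc(-n2cnc3ccc(-c4ccc(C)cc4F)cc32)cc(OC)c1OC`: 56 nM
- compound 2 `COc1cc(-n2cnc3ccc(-c4ccccc4)cc32)cc(OC)c1OC`: 2290 nM

In this assay, compound 2 stands at 2290 nM, the higher of the two numbers. Within the data shown here, the only measured step, a 41-fold higher number from compound 1 to compound 2 (1.61 log units; beyond the scatter), is large and beyond the scatter. It puts phenyl in place of 2-fluoro-4-methylphenyl.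

Compound 3 `COc1cc(-n2cnc3ccc(-c4cccc(O)c4)cc32)cc(OC)c1OC` carries hydroxy in place of hydrogen on an aromatic carbon, with hydroxy in place of hydrogen on an aromatic carbon, so that phenyl becomes 3-hydroxyphenyl. Among the measured compounds shown here, the step to compound 2 bears on this only loosely: it shows that substituents on this ring can matter greatly, but no measured compound carries hydroxy. A smaller move towards a lower number is therefore expected, though a change within the scatter remains possible. The expected change is a 2.5-fold lower number from compound 2 to compound 3 (0.41 log units; beyond the scatter). For compound 3 the estimated value is 900 nM, with an expected range of 150 nM to 4000 nM.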

Compound 3, half-maximal inhibitory concentration: 350 nM
Estimate against measurement, compound 3: 2.6-fold (0.41 log units) above, and the stated range covers the measured number.
By their numbers in this assay, from the lowest: compound 1; then compound 3; then compound 2.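

In this assay, a single hydroxy on an aromatic carbon, meta to a large group, is enough to give a 6.5-fold lower number from compound 2 to compound 3 (0.82 log units; beyond the scatter), so the low numbers on this ring are not confined to the 2-fluoro-4-methylphenyl of compound 1. The 3-hydroxyphenyl group does not match that group, however, as shown by a 6.3-fold higher number from compound 1 to compound 3 (0.80 log units; beyond the scatter), a step beyond the scatter, which leaves compound 1 with the lowest number of the three. Nothing available gives a reason for either step.

The compounds shown leave open whether the effect belongs to hydroxy itself, since neither a methoxy nor an amine stands at this place on the ring. They also leave open whether hydroxy would lower the number further on a ring that also carries fluoro and methyl.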